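Chain change on the nitrogen of compound 2

The compounds below may be only part of what the source reports. "The series", "measured", "known", "first", "only" and "open" are said of these compounds alone.

Measured so far:
compound 1 `C=CCNC(=O)c1ccccc1[Se][Se]c1ccccc1C(=O)NCC=C` — 125000 nM
compound 2 `C=CCn1[se]c2ccccc2c1=O` — 25700 nM

In a functional assay on MCF7 cells (Homo sapiens) for cytotoxicity, read by MTT assay, with a stated time of 24 h (on this read-out lower numbers stand for stronger inhibition and higher numbers for weaker inhibition), compound 1 gives 125000 nM. Among the compounds with values here, compound 2, in this assay, gives 25700 nM, the lower of the two numbers; the gap to compound 1 lies beyond the scatter, but the two structures differ in more than one place, so no single step connects them. Compound 3 `CC(C)CCn1[se]c2ccccc2c1=O` has not been measured. It differs from compound 2 by isobutyl in place of vinyl on a saturated chain carbon bound to an aromatic nitrogen; the same difference, cut one bond further out, reads allyl to isopentyl. The core is unchanged, and the two measured values give no indication of how the chain on that nitrogen matters. Within the data shown here, the expectation for this assay is no step beyond the scatter in either direction, with a wide range, since the change has no measured precedent in this set. Compound 3 is estimated at 25000 nM (range 8000 nM to 80000 nM). The step from compound 2 to compound 3 is expected to be a 1.0-fold lower number from compound 2 to compound 3 (0.01 log units; within the scatter).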

Compound 3, half-maximal inhibitory concentration: 29000 nM
The estimate for compound 3 lay 1.2-fold (0.06 log units) below the measured number; measured number inside the range.
By their numbers in this assay, from the lowest: compounds 2 and 3 (each within the scatter of the next); then compound 1.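

In this assay, within the data shown here, the first one-place step, isobutyl in place of vinyl on a saturated chain carbon bound to an aromatic nitrogen, gives a 1.1-fold higher number from compound 2 to compound 3 (0.05 log units; within the scatter) and so stays within the scatter. At this position, then, the exchange of allyl for isopentyl, which also removes the double bond outside aromatic rings, leaves the read-out unmoved for this one pair, and the chain can be changed here without a readable shift. Nothing measured on these compounds bears on why the two chains read alike. Going by these compounds, whether a chain carrying an amine or a carboxylic acid, or a much longer chain, would also leave the number in place stays open. Compound 1 differs from the others in more than one place, so its gap cannot be assigned to any single change.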